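A few compounds are considered here, and "the series" means these few. Any claim that something is new, unique, unknown or untested is made for them only; others in the source may bear on it.

Going by the values given here, the three measured members share one core and differ only at one aromatic carbon. Compound 1 `CCCCCCCCS(=O)(=O)Nc1ccc(-c2ccc(CCCC)cc2)cc1C(=O)O` gives 9000 nM in an assay on mitochondria (strain BALB/c) for inhibition of glycerol-3-phosphate acyltransferase 1, mitochondrial (Mus musculus), read by scintillation counting, with a stated time of 10 min; on this read-out lower numbers stand for stronger inhibition and higher numbers for weaker inhibition. Compound 2 `CCCCCCCCS(=O)(=O)Nc1ccc(-c2ccc(OC)cc2)cc1C(=O)O` gives 19500 nM in this assay, and compound 3 `CCCCCCCCS(=O)(=O)Nc1ccc(-c2ccccc2O)cc1C(=O)O` gives 61700 nM in this assay. Compound 3 thus holds the highest number of the three; the steps of a 6.9-fold higher number from compound 1 to compound 3 (0.84 log units; beyond the scatter) and a 3.2-fold higher number from compound 2 to compound 3 (0.50 log units; beyond the scatter) are both beyond the scatter, so it is the weakest inhibitor shown. Compound 4 `CCCCCCCCS(=O)(=O)Nc1ccc(/C=C/c2ccccc2)cc1C(=O)O` differs from compound 3 by 2-phenylethenyl in place of 2-hydroxyphenyl on an aromatic carbon. Among the compounds with values here, the steps that bear on this are a 6.9-fold higher number from compound 1 to compound 3 (0.84 log units; beyond the scatter) and a 3.2-fold higher number from compound 2 to compound 3 (0.50 log units; beyond the scatter), both running from a group with no hydrogen-bond donor to the 2-hydroxyphenyl, while a 2.2-fold higher number from compound 1 to compound 2 (0.34 log units; beyond the scatter) is smaller. Going back from the donor-bearing group to one with no hydrogen-bond donor or acceptor, a lower number beyond the scatter is expected in this assay. Within the data shown here, no measured compound carries the entering group, and the expected step is therefore placed short of a full return to compound 1, as a 4.1-fold lower number from compound 3 to compound 4 (0.61 log units; beyond the scatter). Compound 4 is estimated at 15000 nM, with a range of 5000 nM to 45000 nM.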

Compound 4, half-maximal inhibitory concentration: 16300 nM
Compound 4: the middle estimate sits 1.1-fold (0.04 log units) below what was measured; the measured number falls inside the stated range.
By their numbers in this assay, from the lowest: compounds 1, 4 and 2 (each within the scatter of the next, the first and the last beyond it); then compound 3.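

In this assay, the step to 2-phenylethenyl gives a 3.8-fold lower number from compound 3 to compound 4 (0.58 log units; beyond the scatter), so this aromatic carbon accepts a group with no hydrogen-bond donor or acceptor and a double bond outside aromatic rings, not only a directly attached substituted phenyl. The further readings, a 1.2-fold lower number from compound 2 to compound 4 (0.08 log units; within the scatter) and a 1.8-fold higher number from compound 1 to compound 4 (0.26 log units; within the scatter), both lie within the scatter, so 2-phenylethenyl cannot be ordered against either 4-methoxyphenyl or 4-butylphenyl, and among the four compounds only the 2-hydroxyphenyl of compound 3 stands apart from all the others. No supporting data bear on the origin of this difference.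

A plain phenyl group would show whether the hydroxyl or the absence of a larger substituent sets compound 3 apart. The saturated 2-phenylethyl group would test whether the double bond matters, and an aminophenyl group would test a different donor.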